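Oxygen to Sulfur on an Amine Nitrogen: Expected Cytotoxicity

This account rests on a few compounds, and the source may have more. Where it says the series, first, only, none or still open, it means among the compounds named here.

Compound 1 `COc1ccc(-c2nc3cc(/C(C)=N/NC(N)=O)ccc3[nH]2)cc1` and compound 2 `COc1ccc(-c2nc3cc(/C(C)=N/NC(N)=S)ccc3[nH]2)cc1` share one core and differ only in this way: a group of 3 heavy atoms (1 carbon, 1 nitrogen, 1 sulfur; no ring) in place of a group of 3 heavy atoms (1 carbon, 1 nitrogen, 1 oxygen; no ring), on an amine nitrogen. In an ADME assay on MDBK cells (Bos taurus) for cytotoxicity, read by MTT assay, with a stated time of 96 h (on this read-out lower numbers stand for higher toxicity in this test and higher numbers for lower toxicity in this test), compound 1 gives 25000 nM. In this assay compound 2 gives 13000 nM. The step between them is a 1.9-fold lower number from compound 1 to compound 2 (0.28 log units; within the scatter), so the two values cannot be told apart by this test.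

Compound 3 `C/C(=N\NC(N)=O)c1ccc2c(c1)nc(-c1ccccc1)n2C1CCCCC1` is built on a different core; how the two cores differ is not broken down here. In this assay compound 3 gives > 100000 nM, which is a limit of the assay rather than a number. That is the limit of > 100000 nM in this assay, at which 1 of the 3 values shown sits.

Compound 4 `C/C(=N\NC(N)=S)c1ccc2c(c1)nc(-c1ccccc1)n2C1CCCCC1` stands to compound 3 as compound 2 stands to compound 1: a group of 3 heavy atoms (1 carbon, 1 nitrogen, 1 sulfur; no ring) in place of a group of 3 heavy atoms (1 carbon, 1 nitrogen, 1 oxygen; no ring), on an amine nitrogen. The place is the same in both cases, so this is the same change. Because the same change earlier gave a 1.9-fold lower number from compound 1 to compound 2 (0.28 log units; within the scatter), compound 4 is expected to show a step that the limit leaves unreadable from compound 3 to compound 4. The value of compound 3 is a limit, and the reading for compound 4 is expected to fall near it as well. The estimate for compound 4 is 150000 nM, expected to lie between 60000 nM and 400000 nM.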

Compound 4, half-maximal cytotoxic concentration: 24000 nM
Compound 4: middle estimate off by 6.3-fold (0.80 log units), on the high side; measured number outside the range, below it.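

On the core of compound 3, the sulfur-bearing group in place of the carbamoyl group, on an amine nitrogen, gives an at least 4.1-fold lower number from compound 3 to compound 4 (0.61 log units; beyond the scatter) in this assay, and on this read-out a lower number stands for higher toxicity in this test. The value of compound 3, > 100000 nM, is a limit of the assay and not a number. On the core of compound 1 the same change stays within the scatter, so the data neither show that its size carries over from one core to the other nor show that it differs: the same change on two cores in this assay, a 1.9-fold lower number (0.28 log units; within the scatter) from compound 1 to compound 2 and an at least 4.1-fold lower number (0.61 log units; beyond the scatter) from compound 3 to compound 4; the limit leaves it open whether they differ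

The compounds shown leave open whether a third core, such as one carrying an amine or a carboxylic acid on its phenyl ring, would respond to this change in the same way. Also open, from the compounds shown here alone, is how an acetyl group in place of the carbamoyl group, on the same amine nitrogen, would read in this assay.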